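The compounds below may be only part of what the source reports. "The series", "measured", "known", "first", "only" and "open" are said of these compounds alone.

Compound 2 `CNCc1cc(-c2cccnc2F)n(S(=O)(=O)c2cccs2)c1` stands level with compound 1 `CNCc1cc(-c2cccnc2F)n(S(=O)(=O)c2cccnc2)c1`: in a functional assay on the whole organism (strain Jcl:Sprague-Dawley) for inhibition, with Rattus norvegicus as the target, with stated times of 3 min and 3 h, at a dose of 1 mg/kg by the intravenous route (on this read-out lower numbers stand for less inhibition and higher numbers for more inhibition at the one dose given (going by the name of the read-out)), compound 1 gives 96%, and in this assay compound 2 gives 96%, so no change at the digits printed from compound 1 to compound 2 (within the scatter). Compound 3 `CNCc1cc(-c2cccnc2F)n(S(=O)(=O)c2ccccn2)c1` differs from compound 2 in one place: pyridin-2-yl in place of thiophen-2-yl on a sulfonyl sulfur. Among the measured compounds shown here, the only step that bears on it, the exchange of one aryl on that sulfonyl sulfur for another, left the read-out unchanged within the scatter, and the read-out already sits near the top of its range; no step beyond the scatter is therefore expected, a number 2 percentage points lower from compound 2 to compound 3 (within the scatter). Compound 3 is expected to give 94%, within 82% to 100%.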

Compound 3, a percentage reported as inhibition, in the whole organism at one dose (the size of the read-out at that dose, not a potency): 81%
Compound 3: the middle estimate sits 13 percentage points above what was measured; the measured number lies below the stated range.
By their numbers in this assay, from the lowest: compound 3; then compounds 1 and 2 (each within the scatter of the next).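

On this sulfonyl sulfur the aryl groups are not interchangeable in this assay: pyridin-2-yl in place of thiophen-2-yl gives a number 15 percentage points lower from compound 2 to compound 3 (beyond the scatter), and pyridin-2-yl in place of pyridin-3-yl gives a number 15 percentage points lower from compound 1 to compound 3 (beyond the scatter). The read-out therefore separates two pyridinyl groups, so a six-membered aromatic ring as such does not set the outcome, since compound 1 carries one and stays level with compound 2. Nothing available explains this difference. The compounds shown leave open whether phenyl or pyridin-4-yl on that sulfur would stand with compound 1 or with compound 3.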